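The source may hold more compounds than are shown below. What is called first, only, known or untested is meant among the compounds shown, and "the series" means these compounds.

Three compounds from one series share a core and differ only in the ring attached to it. Compound 1 `CC(C)Oc1ccc(-c2nnc(-c3ccccc3)s2)cc1Cl` carries a phenyl there; in a physicochemical assay for lipophilicity, at pH 7.4 (on this read-out lower numbers stand for lower lipophilicity and higher numbers for higher lipophilicity), compound 1 gives 8.65. Compound 2 `CC(C)Oc1ccc(-c2nnc(-n3cncn3)s2)cc1Cl` carries a 1H-1,2,4-triazol-1-yl instead, and in this assay compound 2 gives 6.18. Compound 3 `CC(C)Oc1ccc(-c2nnc(-c3cn[nH]c3)s2)cc1Cl` carries a 1H-pyrazol-4-yl, and in this assay compound 3 gives 5, the lowest of the three numbers. The ring exchanges moved the read-out far: a number 2.47 log units lower from compound 1 to compound 2 (beyond the scatter), a number 3.65 log units lower from compound 1 to compound 3 (beyond the scatter) and a number 1.18 log units lower from compound 2 to compound 3 (beyond the scatter).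

Compound 4 `Cc1[nH]ncc1-c1nnc(-c2ccc(OC(C)C)c(Cl)c2)s1` differs from compound 3 by a far smaller change, (methyl in place of hydrogen on an aromatic carbon). Among the compounds with values here, none of the measured steps involves a methyl entering in place of a hydrogen; each of them swaps one whole ring for another, so they bear on compound 4 only as a reminder that the present change is much smaller than any of them. A single added carbon with no ring and no donors or acceptors is expected to shift this assay only slightly, at most a little upward.

For compound 4 the expected step is a number 0.40 log units higher from compound 3 to compound 4 (beyond the scatter), giving an estimated value of 5.4, with a range from 5 to 5.8.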

Compound 4, distribution coefficient: 5.45
Compound 4: middle estimate off by 0.05 log units, on the low side; measured number inside the range.
By their numbers in this assay, from the lowest: compound 3; then compound 4; then compound 2; then compound 1.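

In this assay, a methyl in place of hydrogen on this aromatic carbon, next to the ring nitrogen and next to the ring atom that bears a large group, gives a number 0.45 log units higher from compound 3 to compound 4 (beyond the scatter) and so shows that this position of the 1H-pyrazol-4-yl ring responds to one added carbon, though by much less than any of the whole-ring exchanges. The methyl does not undo those exchanges, since the 5-methyl-1H-pyrazol-4-yl ring still leaves a number 0.73 log units lower from compound 2 to compound 4 (beyond the scatter) and a number 3.20 log units lower from compound 1 to compound 4 (beyond the scatter) in the same assay, placing compound 4 closer to compound 3 than to either of the other two compounds. No measurement shown here accounts for the size of this methyl step.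

Going by these compounds, whether an ethyl, a trifluoromethyl, an amine or a carboxylic acid at this same carbon would move the read-out further upward, leave it in place or bring it down remains open. On these data alone, it is also open whether a methyl on the 1H-1,2,4-triazol-1-yl ring or on the phenyl would shift the number by a similar amount, as a single step says nothing about other rings.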